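A few compounds are considered here, and "the series" means these few. Any claim that something is new, unique, unknown or untested is made for them only; others in the source may bear on it.

Compound 1, `N#Cc1ccc(NC(=O)c2cc(-c3ccccc3)ccc2O)cc1`: 1300 nM
Compound 2, `O=C(Nc1cc(C(F)(F)F)cc(C(F)(F)F)c1)c1ccc(-c2ccccc2)cc1O`: 860 nM
Compound 3, `O=C(Nc1ccc(C(F)(F)F)cc1)c1ccc(Br)cc1O`: 340 nM

In a functional assay on KG-1 cells (Homo sapiens) for cytotoxicity, read by luminescence and CellTiter-Glo, with a stated time of 3 days (on this read-out higher numbers stand for weaker inhibition and lower numbers for stronger inhibition), compound 1 gives the highest of the three numbers. Compound 2 sits within the usual scatter of it, so the two cannot be told apart, while compound 3 gives a lower number, beyond the scatter. Compound 4, `N#Cc1ccc(NC(=O)c2cc(Br)ccc2O)cc1`, differs from compound 1 in one place: bromo in place of phenyl on an aromatic carbon. Among the compounds with values here, no two measured compounds differ in only one place, so no measured step shows what this change does. Compound 3 also carries bromo on its core, but it differs from compound 1 elsewhere as well. A modest step toward a lower number is expected, a 2.0-fold lower number from compound 1 to compound 4 (0.30 log units; within the scatter). Compound 4 is estimated at 650 nM, with a range from 250 nM to 1600 nM.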

Compound 4, half-maximal inhibitory concentration: 1290 nM
Estimate against measurement, compound 4: 2.0-fold (0.30 log units) below; measured number inside the range.
By their numbers in this assay, from the lowest: compound 3; then compounds 2, 4 and 1 (each within the scatter of the next).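

In this assay, putting bromo in place of phenyl on this aromatic carbon, para to a hydroxy group, gives a 1.0-fold lower number from compound 1 to compound 4 (0.00 log units; within the scatter). A six-carbon aromatic ring and a single bromine atom therefore cannot be told apart at this position on the core of compound 1, so the phenyl ring shows no measurable contribution to the read-out here. Nothing measured explains why these two groups read alike. The compounds shown leave open what an amine, a carboxylic acid or a longer chain would do on this carbon. They also leave open whether the same swap would read alike with other groups elsewhere on the core.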